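From thiophen-2-yl to furan-2-yl on a shared core

The compounds below may be only part of what the source reports. "The series", "measured", "known", "first", "only" and "open" are said of these compounds alone.

compound 1 `c1coc(-c2ccnc(-c3cccs3)c2)c1` gives 118000 nM
compound 2 `C(=C/c1ccco1)\c1cc(-c2ccco2)cc(-c2cccs2)n1` gives 118000 nM
compound 3 `c1ccc(-c2cc(-c3ccco3)ccn2)nc1` gives 118000 nM

All three compounds were tested in a functional assay on HCT-15 cells (Homo sapiens) for antiproliferative activity (a higher number here means that more compound is needed for the effect, a lower number that less compound is needed), and their values are identical at the digits shown, so compound 1 stands level with compounds 2 and 3. The next compound to consider is compound 4 `c1coc(-c2ccnc(-c3ccco3)c2)c1`, which differs from compound 1 in one place: furan-2-yl in place of thiophen-2-yl on an aromatic carbon. In words, furan-2-yl takes the place of thiophen-2-yl on an aromatic carbon, next to the ring nitrogen.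

No measurement here tests this swap directly. Within the data shown here, the one measured step, no change at the digits printed from compound 1 to compound 2 (within the scatter), is a different change: 2-(furan-2-yl)ethenyl in place of hydrogen on an aromatic carbon. With that step inside the scatter, and with compound 3 also giving 118000 nM, no step beyond the scatter is expected in this assay for the swap.

The expected step is no change at the digits printed from compound 1 to compound 4 (within the scatter), and this remains an estimate.

For compound 4 the estimated value is 118000 nM, with an expected range from 60000 nM to 200000 nM.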

Compound 4, half-maximal effective concentration: 118000 nM
The estimate for compound 4 equals the measured number at the digits printed; low and high end bracket the measured number.
By their numbers in this assay, from the lowest: compounds 1, 2, 3 and 4 (each within the scatter of the next).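

In this assay furan-2-yl in place of thiophen-2-yl on an aromatic carbon, next to the ring nitrogen, gives no change at the digits printed from compound 1 to compound 4 (within the scatter) and so extends the picture: the earlier step added a group, whereas this one exchanges the group already at this position. The two groups have the same number of heavy atoms and the same five-membered aromatic ring, and differ in its hetero atom, sulfur leaving and oxygen entering, so this exchange of sulfur for oxygen does not separate the two compounds in this read-out. No supporting measurement is available to explain this result.

The compounds shown cover only aromatic rings at this position. From the compounds shown here alone, whether an amine, a carboxylic acid or a longer chain there would move the value remains open.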